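Phenyl for chloro on the para-acyl arm of compound 3

The source may hold more compounds than are shown below. What is called first, only, known or untested is meant among the compounds shown, and "the series" means these compounds.

Of the compounds shown here, three have been measured in a functional assay on A498 cells (Homo sapiens) for inhibition, read by sulforhodamine B assay, with a stated time of 48 h, tested at 10 uM; on this read-out lower numbers stand for less inhibition of growth and higher numbers for more inhibition of growth at the one concentration tested. Compound 1 `CC(=O)c1ccc(Nc2ccnc(SCC(=O)c3ccc(Br)cc3)n2)cc1` gives 19%. Compound 2 `CC(=O)c1cccc(Nc2ccnc(SCC(=O)c3ccc(-c4ccccc4)cc3)n2)c1` gives 40%. Compound 3 `CC(=O)c1ccc(Nc2ccnc(SCC(=O)c3ccc(Cl)cc3)n2)cc1` gives 19%, which puts it level with compound 1 and together with it at the bottom of the three numbers; compound 2 sits higher by a margin beyond the scatter. Going by the values given here, the only single-point step measured so far, no change at the digits printed from compound 1 to compound 3 (within the scatter), swaps one halogen for another and moves nothing.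

Compound 4 `CC(=O)c1ccc(Nc2ccnc(SCC(=O)c3ccc(-c4ccccc4)cc3)n2)cc1` is the next member to be measured. It differs from compound 3 by phenyl in place of chloro on an aromatic carbon. Among the compounds with values here, no measured step replaces a halogen with a phenyl, so the step from compound 1 to compound 3 does not bear on it directly; it only shows that the halogen itself is not what sets the level of compound 3. Within the data shown here, compound 2, which also bears a phenyl, gives 40%, but no single-point step links it to compound 4, so its value is a hint and not a measured step. The estimated step of a number 14 percentage points higher from compound 3 to compound 4 (beyond the scatter) is therefore expected to be upward but modest. Compound 4 is estimated at 33%, within 14% to 52%.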

Compound 4, percent growth inhibition at one concentration: 55%
The estimate for compound 4 lay 22 percentage points below the measured number; the whole stated range lies below it.
By their numbers in this assay, from the lowest: compounds 1 and 3 (each within the scatter of the next); then compound 2; then compound 4.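

In this assay the position on the aromatic carbon para to a large group responds strongly to the size of what it carries: the step of a number 36 percentage points higher from compound 3 to compound 4 (beyond the scatter) and the step of a number 36 percentage points higher from compound 1 to compound 4 (beyond the scatter) both replace a single halogen atom with phenyl, while the halogen exchange alone, no change at the digits printed from compound 1 to compound 3 (within the scatter), moved nothing. The other arm of the molecule also counts, since the step of a number 15 percentage points higher from compound 2 to compound 4 (beyond the scatter) shows that 4-acetylphenyl in place of 3-acetylphenyl on the nitrogen matters with the phenyl held constant, though this step is modest where the two phenyl-for-halogen steps are large. Nothing among the data available explains either rise.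

Going by these compounds, it remains open whether the gain belongs to the aromatic ring or simply to the number of heavy atoms, which a cyclohexyl or a pyridyl in place of the phenyl would help to separate, and whether a morpholine or a carboxylic acid on that carbon would keep it. On these data alone, the 3-acetylphenyl arm appears here only with the phenyl, so whether the two changes act independently also stays open.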